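Hydroxymethyl chain in place of 1-isopropylpropyl on compound 3

This account rests on a few compounds, and the source may have more. Where it says the series, first, only, none or still open, it means among the compounds named here.

In a functional assay on HeLa cells (Homo sapiens) for cytotoxicity, read by WST assay, with a stated time of 48 h (on this read-out higher numbers stand for weaker inhibition and lower numbers for stronger inhibition), compound 3 `CC[C@H](C(C)C)C(c1ccc(O)c(OC)c1)c1ccc(O)c(OC)c1` gives 9700 nM. Compound 2 `COc1cc(C(c2ccc(O)c(OC)c2)[C@H](CF)C(C)C)ccc1O`, with a 1-(fluoromethyl)-2-methylpropyl chain, gives 19000 nM. The gap between these two is a 2.0-fold lower number from compound 2 to compound 3 (0.29 log units; within the scatter), so they stand level. Compound 1 `COC[C@H](C)[C@H](C)C(c1ccc(O)c(OC)c1)c1ccc(O)c(OC)c1` gives 72000 nM, well apart from both.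

The next compound to be tested is compound 4 `COc1cc(C(c2ccc(O)c(OC)c2)[C@H](C)[C@@H](C)CO)ccc1O`. The change is 2-(hydroxymethyl)-1-methylpropyl in place of 1-isopropylpropyl on a saturated chain carbon bound to two aromatic carbons.

For the measured compounds named here, no measured compound carries a hydroxymethyl chain. The closest measured match is the 2-(methoxymethyl)-1-methylpropyl chain of compound 1. Two measured steps leave that chain, and both are modest: a 3.8-fold lower number from compound 1 to compound 2 (0.58 log units; beyond the scatter) and a 7.4-fold lower number from compound 1 to compound 3 (0.87 log units; beyond the scatter). The second has the same two chains as the planned change, apart from the methyl on the oxygen, and it runs in the opposite direction. A step of similar modest size is therefore expected in this assay, towards a higher number and beyond the scatter. The estimated step is a 6.2-fold higher number from compound 3 to compound 4 (0.79 log units; beyond the scatter). For compound 4 the estimated value is 60000 nM, with an expected range of 25000 nM to 140000 nM.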

Compound 4, half-maximal inhibitory concentration: > 100000 nM
Compound 4 was reported as a limit; the forecaster's own chance of this, stated with the estimate: 25%; at least 1.6-fold (0.22 log units) between middle value and limit.
By their numbers in this assay, from the lowest: compounds 3 and 2 (each within the scatter of the next); then compound 1. At a limit, above all of these: compound 4.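

In this assay compound 4 is reported only as a limit, > 100000 nM, so the steps to it are floors. For the compounds shown here, putting 2-(hydroxymethyl)-1-methylpropyl in place of the all-carbon 1-isopropylpropyl on a saturated chain carbon bound to two aromatic carbons gives an at least 10-fold higher number from compound 3 to compound 4 (1.01 log units; beyond the scatter), the first large step at this position, and the fluorine-bearing chain gives a floor also beyond the scatter, an at least 5.2-fold higher number from compound 2 to compound 4 (0.72 log units; beyond the scatter). The methyl on the oxygen is the only difference in an at least 1.3-fold higher number from compound 1 to compound 4 (0.14 log units; that floor lies within the scatter), which cannot be read as a step, so the hydroxyl chain and its methyl ether are not separated, and both stand on the high-number side of the two remaining compounds in the series.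

An amine or a carboxylic acid in place of the hydroxyl, or a longer chain carrying the same hydroxyl, lies outside the compounds shown, so it remains open whether the high numbers extend to other groups at the chain end. How far compound 4 lies past its reported value also stays open: the limit of > 100000 nM in this assay, at which 1 of the 4 values shown sits.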